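The source may report more compounds than this note shows. Statements on the series, on what has been measured and on what is new or still open speak of the compounds shown alone.

Measured in a toxicity assay on GES1 cells (Homo sapiens) for inhibition, read by MTT assay, with a stated time of 72 h; on this read-out lower numbers stand for stronger inhibition and higher numbers for weaker inhibition:
- compound 1 `Cc1cc(N2CC[C@@H](C)[C@@H](N(C)c3ncnc4[nH]ccc34)C2)n2nc(SCc3ccccc3)nc2n1`: 67200 nM
- compound 2 `Cc1cc(N2CC[C@@H](C)[C@@H](N(C)c3ncnc4[nH]ccc34)C2)n2ncnc2n1`: 57900 nM
- compound 3 `Cc1cc(N2CC[C@@H](C)[C@@H](N(C)c3ncnc4[nH]ccc34)C2)n2nc(SCC3CC3)nc2n1`: 27900 nM

Compound 3 has the lowest number of the three at 27900 nM, and its steps to the other two are modest but beyond the scatter. Compound 4 `Cc1cc(N2CC[C@@H](C)[C@@H](N(C)c3ncnc4[nH]ccc34)C2)n2nc(SCc3ccccc3Br)nc2n1` has not yet been measured. The change from compound 3 is 2-bromophenyl in place of cyclopropyl on a saturated chain carbon bound to a sulfur. In words, 2-bromophenyl stands in place of cyclopropyl on a saturated chain carbon bound to a sulfur.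

The closest measured step is a 2.4-fold lower number from compound 1 to compound 3 (0.38 log units; beyond the scatter), which swaps phenyl for cyclopropyl at that same place. Read in reverse, it points towards a higher number when an aromatic ring returns. The step of a 2.1-fold lower number from compound 2 to compound 3 (0.32 log units; beyond the scatter) shows the cyclopropylmethyl compound also lying lower than the compound without a sulfanyl group, while a 1.2-fold lower number from compound 1 to compound 2 (0.06 log units; within the scatter) shows no change beyond the scatter. Within the data shown here, no measured compound carries bromine, so its contribution is unknown, and this widens the range.

In this assay, a modest step towards a higher number is therefore expected. The estimated step is a 2.1-fold higher number from compound 3 to compound 4 (0.32 log units; beyond the scatter). Compound 4 is expected at 58000 nM, with an estimated range from 26000 nM to 120000 nM.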

Compound 4, half-maximal inhibitory concentration: > 100000 nM
Compound 4: no number, only a limit; the forecaster's own chance of this, stated with the estimate: 10%; at least 1.7-fold (0.23 log units) between middle value and limit.
By their numbers in this assay, from the lowest: compound 3; then compounds 2 and 1 (each within the scatter of the next). At a limit, above all of these: compound 4.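

In this assay, compound 4 gives a limit of the assay and not a number: the limit of > 100000 nM in this assay, at which 1 of the 4 values shown sits.

Among these compounds, on the saturated chain carbon bound to a sulfur, 2-bromophenyl in place of cyclopropyl brings an at least 3.5-fold higher number from compound 3 to compound 4 (0.55 log units; beyond the scatter), so a substituted aromatic ring at this place moves the number up by at least a modest step, which is the first such step measured upward from compound 3 with bromine present. The other two comparisons stay unresolved, with an at least 1.7-fold higher number from compound 2 to compound 4 (0.23 log units; that floor lies within the scatter) and, for bromo in place of hydrogen on an aromatic carbon, an at least 1.4-fold higher number from compound 1 to compound 4 (0.17 log units; that floor lies within the scatter); since both floors lie within the scatter, neither the whole (2-bromobenzyl)sulfanyl group nor the bromo alone is shown to change the result.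

On these data alone, how far compound 4 lies past its limit remains unknown, and so does the true size of all three steps. The compounds shown also leave open whether a chloro or methoxy group on the benzyl ring, an amine or a carboxylic acid there, or a longer chain in place of cyclopropylmethyl would move the number at this place.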